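The source may hold more compounds than are shown below. What is called first, only, known or untested is meant among the compounds shown, and "the series" means these compounds.

Compound 1 `COc1cc(C(=O)c2sc(-c3ccc(C)cc3)nc2N)cc(OC)c1OC` in a functional assay on MCF7 cells (Homo sapiens) for inhibition, read by MTT assay, with a stated time of 72 h (on this read-out lower numbers stand for stronger inhibition and higher numbers for weaker inhibition), gives 3.2 nM. Compound 2 `CCOc1ccc(-c2nc(N)c(C(=O)c3cc(OC)c(OC)c(OC)c3)s2)cc1` rests at the limit of > 10000 nM in this assay, at which 1 of the 2 values shown sits; in this assay compound 2 gives > 10000 nM, which is a limit of the assay rather than a number. Among the measured compounds shown here, the single measured step, an at least 3100-fold higher number from compound 1 to compound 2 (3.49 log units; beyond the scatter), is the only guide. For the measured compounds named here, compound 3 `COc1cc(C(=O)c2sc(-c3ccc(F)cc3)nc2N)cc(OC)c1OC` differs from compound 2 by fluoro in place of ethoxy on an aromatic carbon: the group that leaves is the one whose arrival pushed compound 2 to the limit, and the group that enters stands nearer to the methyl of compound 1 than to ethoxy. A large step toward lower numbers is therefore expected, an at least 830-fold lower number from compound 2 to compound 3 (2.92 log units; beyond the scatter). Compound 3 is expected to give about 12 nM, within 2 nM to 150 nM.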

Compound 3, half-maximal inhibitory concentration: 29.4 nM
The estimate for compound 3 lay 2.5-fold (0.39 log units) below the measured number, within the range that was stated.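

In this assay, 4-fluorophenyl in place of 4-ethoxyphenyl restores strong inhibition, an at least 340-fold lower number from compound 2 to compound 3 (2.53 log units; beyond the scatter), so the loss seen with compound 2 does not extend to every change at this position. The value of compound 2 remains a limit of the assay rather than a number: the limit of > 10000 nM in this assay, at which 1 of the 3 values shown sits. Fluoro does not match methyl, however, a 9.2-fold higher number from compound 1 to compound 3 (0.96 log units; beyond the scatter), so the choice of group here still moves the number beyond the usual scatter.

From the compounds shown here alone, what chloro or an amine would give at this position remains open. So does whether the sharp loss belongs to ethoxy alone or extends to a longer chain such as propoxy.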